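Swapping the Aryl Group on the Ketone of a Shared Core

The source may report more compounds than this note shows. Statements on the series, on what has been measured and on what is new or still open speak of the compounds shown alone.

Compound 1 `Cn1cccc1C(=O)/C=C/c1ccc2c(c1)B(O)OC2` — > 100000 nM
Compound 2 `CCc1ccc(C(=O)/C=C/c2ccc3c(c2)B(O)OC3)cc1` — 10900 nM
Compound 3 `CCOC(=O)c1ccc(C(=O)/C=C/c2ccc3c(c2)B(O)OC3)cc1` — 7600 nM

In a functional assay on HCT-116 cells (Homo sapiens) for cytotoxicity, read by MTT assay, with a stated time of 48 h (on this read-out lower numbers stand for stronger inhibition and higher numbers for weaker inhibition), compound 1 gives > 100000 nM, which is a limit of the assay and not a number, namely (the limit of > 100000 nM in this assay, at which 1 of the 3 values shown sits). Compound 2 gives 10900 nM and compound 3 gives 7600 nM; between them stands a 1.4-fold lower number from compound 2 to compound 3 (0.16 log units; within the scatter). Compound 4 `Cc1cccc(C(=O)/C=C/c2ccc3c(c2)B(O)OC3)c1` differs from compound 1 by 3-methylphenyl in place of 1-methyl-1H-pyrrol-2-yl on a carbonyl carbon. Among the measured compounds shown here, the only measured step concerns a substituent on an aromatic carbon of a six-membered ring and does not cover this exchange, so no step size can be taken from it. Compounds 2 and 3 both carry a six-membered carbon ring on the carbonyl carbon and sit far from the limit of compound 1. Compound 4 is therefore expected to land near them, estimated at 12000 nM with a range of 4000 nM to 60000 nM. This expected step is an at least 8.3-fold lower number from compound 1 to compound 4 (0.92 log units; beyond the scatter).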

Compound 4, half-maximal inhibitory concentration: 6700 nM
The estimate for compound 4 lay 1.8-fold (0.25 log units) above the measured number; low and high end bracket the measured number.
By their numbers in this assay, from the lowest: compounds 4, 3 and 2 (each within the scatter of the next). At a limit, above all of these: compound 1.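

In this assay, the exchange of the whole ring on the carbonyl carbon gives a large change: an at least 14-fold lower number from compound 1 to compound 4 (1.17 log units; beyond the scatter). Unlike the earlier substituent exchange on an aromatic carbon, which stayed within the scatter, this step lies beyond it. Compound 1 stands at a limit of the assay and not at a number, so the step has no upper end: the limit of > 100000 nM in this assay, at which 1 of the 4 values shown sits.

The compounds shown leave open whether the methyl on the 3-methylphenyl ring contributes to this change. They also do not show how a pyridine ring or an unmethylated pyrrole ring on the carbonyl carbon would read.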